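A Nitrile Added Once More, on a Second Core

The compounds below may be only part of what the source reports. "The series", "measured", "known", "first", "only" and "open" are said of these compounds alone.

Of the compounds shown here, three have been measured in a functional assay on HCT-116 cells (Homo sapiens) for cytotoxicity, read by scintillation counting and thymidine incorporation, with a stated time of 72 h; a higher number here means a weaker inhibitor, a lower number a stronger inhibitor. Compound 1 `CCOc1cc(C(=CC#N)c2ccc(OC)c(N)c2)ccc1OC` gives 19 nM in this assay. Compound 2 `C=C(c1ccc(OC)c(N)c1)c1ccc(OC)c(OCC)c1` gives 38 nM, and compound 3 `C=C(c1cc(OC)cc(OC)c1)c1ccc(OC)c(O)c1` gives 21 nM. Compounds 1 and 2 differ in one place only, (cyano in place of hydrogen on a double-bonded chain carbon bound to a double-bonded chain carbon), and the step recorded for this change is a 2.0-fold lower number from compound 2 to compound 1 (0.30 log units; within the scatter), so the two values sit within the usual scatter of each other. Compound 3 stands close to compound 1, and the difference between the core of compound 3 and the core of compound 2 is not broken down here.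

Compound 4 `COc1cc(OC)cc(C(=CC#N)c2ccc(OC)c(O)c2)c1` has not yet been measured. It differs from compound 3 by cyano in place of hydrogen on a double-bonded chain carbon bound to a double-bonded chain carbon, which is the same change that carries compound 2 to compound 1: the place is described in identical words for both pairs. For the measured compounds named here, the only guide to its size is the earlier step, a 2.0-fold lower number from compound 2 to compound 1 (0.30 log units; within the scatter), which did not leave the scatter. On that basis compound 4 is expected to show a step of a 1.8-fold lower number from compound 3 to compound 4 (0.24 log units; within the scatter) from compound 3, because the earlier step of a 2.0-fold lower number from compound 2 to compound 1 (0.30 log units; within the scatter) was small. Compound 4 is therefore estimated at 12 nM in this assay. The expected range for compound 4 runs from 4 nM to 40 nM, wide enough to cover the scatter seen in repeated measurements of this kind.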

Compound 4, half-maximal inhibitory concentration: 2.5 nM
Beside the measured number, compound 4's estimate is 4.8-fold (0.68 log units) above it; measured number below the stated range.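

In this assay, placing a cyano on the double-bonded chain carbon of the core of compound 3 gave an 8.4-fold lower number from compound 3 to compound 4 (0.92 log units; beyond the scatter), a step that, unlike a 2.0-fold lower number from compound 2 to compound 1 (0.30 log units; within the scatter), stands clear of the scatter. The change therefore did not carry over from one core to the other at a single size, and the size seen on the first core would have been a poor guide to the second: the same change on two cores in this assay, a 2.0-fold lower number (0.30 log units; within the scatter) from compound 2 to compound 1 and an 8.4-fold lower number (0.92 log units; beyond the scatter) from compound 3 to compound 4, 4.2-fold (0.62 log units) apart, beyond the scatter of two such steps
For the compounds shown here, what the two pairs do show is a lower number on both cores, though only the step on the core of compound 3 can be told apart from the scatter, and with just two pairs this does not amount to a rule for the series, nor does it show which feature of the cores sets the steps apart, since the cores differ in more than one place.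

The compounds shown leave open whether a third core would follow the smaller step, the larger one or neither. They also leave open whether a carboxamide, a fluorine or a methyl on the same chain carbon would give a step of similar size to that of the cyano.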